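Pivalamide in Place of the Chlorobutanamide Chain

This account rests on a few compounds, and the source may have more. Where it says the series, first, only, none or still open, it means among the compounds named here.

Compound 1 `O=C(CCl)Nc1ccc(SCC(=O)Nc2ccc(Cl)cn2)cc1` gives 2500 nM in a functional assay on HeLa cells (Homo sapiens) for antiproliferative activity, read by MTT assay, with a stated time of 48 h; on this read-out higher numbers stand for weaker inhibition and lower numbers for stronger inhibition. Compound 2 `O=C(CCCCl)Nc1ccc(SCC(=O)Nc2ccc(Cl)cn2)cc1` reaches only a limit of the assay, > 80000 nM in this assay. Within the data shown here, the move an at least 32-fold higher number from compound 1 to compound 2 (1.50 log units; beyond the scatter) is the one measured step, and it ends at the limit of > 80000 nM in this assay, at which 1 of the 2 values shown sits. Compound 3 `CC(C)(C)C(=O)Nc1ccc(SCC(=O)Nc2ccc(Cl)cn2)cc1` differs from compound 2 by tert-butyl in place of 3-chloropropyl on a carbonyl carbon. Among the measured compounds shown here, no measured step bears directly on this exchange, so he expects no shift beyond the scatter in this assay, and compound 3 is estimated at 80000 nM (range 20000 nM to 300000 nM), meaning an expected step of a number no higher from compound 2 to compound 3 (the limit leaves the size open) from the limit of compound 2.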

Compound 3, half-maximal inhibitory concentration: > 80000 nM
Compound 3 ended at the assay's limit (the forecaster's own chance of this, stated with the estimate: 65%); the middle value lies on the limit itself.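

Replacing chloromethyl with tert-butyl on the carbonyl carbon gives an at least 32-fold higher number from compound 1 to compound 3 (1.50 log units; beyond the scatter) in this assay. So a group without chlorine, not only the longer 3-chloropropyl, falls far short of compound 1. The step between compound 2 and compound 3 cannot be read, and of the three compounds only compound 1 gives a measurable value at this position: the limit of > 80000 nM in this assay, at which 2 of the 3 values shown sit.

On these data alone, it remains open whether the reading of compound 1 depends on the chlorine or on the short chain that carries it. A plain methyl or a bromomethyl on the same carbonyl carbon would separate the two.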